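A Methyl Added on a Sulfonamide Chain

The source may hold more compounds than are shown below. What is called first, only, known or untested is meant among the compounds shown, and "the series" means these compounds.

Of the compounds shown here, three of one study have been measured in a physicochemical assay for lipophilicity; on this read-out lower numbers stand for lower lipophilicity and higher numbers for higher lipophilicity. Compound 1, `CN(CCCn1cc[n+](C)c1/C=N/O)S(C)(=O)=O`, gives -2.63 in this assay. Compound 2, `CCN(CCCn1cc[n+](C)c1/C=N/O)S(C)(=O)=O`, differs from it in one place, (methyl in place of hydrogen on a saturated chain carbon bound to a sulfonamide nitrogen); in this assay compound 2 gives -2.69. The step between them, a number 0.06 log units lower from compound 1 to compound 2 (within the scatter), is a small one. Compound 3, `C[n+]1ccn(CCNS(=O)(=O)C(F)(F)F)c1/C=N/O`, stands highest of the three, and in this assay compound 3 gives -1.2. The difference between the core of compound 1 and the core of compound 3 is not broken down here.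

Compound 4, `CC(Cn1cc[n+](C)c1/C=N/O)NS(=O)(=O)C(F)(F)F`, has not yet been measured. It differs from compound 3 by methyl in place of hydrogen on a saturated chain carbon bound to a saturated chain carbon and a sulfonamide nitrogen. Among the measured compounds shown here, this is the same kind of change as the one from compound 1 to compound 2, though not the same: in compound 4 the carbon that receives the methyl is bound to a saturated chain carbon and a sulfonamide nitrogen, whereas in compound 2 that carbon is bound to a sulfonamide nitrogen only. Because the earlier step of a number 0.06 log units lower from compound 1 to compound 2 (within the scatter) stayed within the scatter, a comparably small step is expected here, a number 0.10 log units higher from compound 3 to compound 4 (within the scatter). Compound 4 is therefore estimated to give -1.1 in this assay, with a likely range from -1.5 to -0.7.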

Compound 4, distribution coefficient: -0.82
The estimate for compound 4 lay 0.28 log units below the measured number, and the stated range covers the measured number.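

In this assay, methyl in place of hydrogen gives a number 0.38 log units higher from compound 3 to compound 4 (beyond the scatter), whereas the same kind of change gave a number 0.06 log units lower from compound 1 to compound 2 (within the scatter) on the core of compound 1, so in these two pairs a step that stayed within the scatter on one core did not stay there on the other. This does not show that the core alone sets the size of the step: in compound 2 the carbon receiving the methyl is bound to a sulfonamide nitrogen only, while in compound 4 it is bound to a saturated chain carbon and a sulfonamide nitrogen, and two pairs are too few to support a rule for the series. Nothing available here accounts for the difference between the two steps.

The compounds shown leave open whether methyl on a saturated chain carbon bound to a saturated chain carbon and a sulfonamide nitrogen would give a comparable step on the core of compound 1. They also leave open how a longer chain such as propyl, or a carboxylic acid, at that same place would read in this assay on either core.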